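Aryl swap on the saturated ring carbon, compound 4

The source may hold more compounds than are shown below. What is called first, only, known or untested is meant among the compounds shown, and "the series" means these compounds.

Measured so far in an assay on cells for inhibition of histone deacetylase 8 (Homo sapiens), read by fluorescence, with a stated time of 30 min; on this read-out higher numbers stand for weaker inhibition and lower numbers for stronger inhibition:
compound 1 `O=C1NC(=O)/C(=C\c2ccc(OCC(=O)N3N=C(c4ccccc4)CC3c3ccccc3)cc2)S1`, 20000 nM
compound 2 `O=C1NC(=O)/C(=C\c2ccc(OCC(=O)N3N=C(c4ccccc4)CC3c3ccccc3Cl)cc2)S1`, 29000 nM
compound 3 `O=C1NC(=O)/C(=C\c2ccc(OCC(=O)N3N=C(c4ccccc4)CC3c3ccc(F)cc3F)cc2)S1`, 34000 nM

All three numbers lie within the scatter of one another, so compound 3 has the highest of the three numbers only nominally: compound 2 is the nearest to it, compound 1 the furthest, and neither gap is beyond the scatter. The three compounds differ only in the aryl group on the saturated ring carbon of the shared core.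

Compound 4 `O=C1NC(=O)/C(=C\c2ccc(OCC(=O)N3N=C(c4ccccc4)CC3c3ccc(Cl)c(Cl)c3)cc2)S1` continues this variation: 3,4-dichlorophenyl in place of 2,4-difluorophenyl on a saturated ring carbon.

Among the compounds with values here, the steps that bear on it are those that changed the same aryl group. From compound 1 to compound 3 the change was a 1.7-fold higher number from compound 1 to compound 3 (0.23 log units; within the scatter); from compound 2 to compound 3 it was a 1.2-fold higher number from compound 2 to compound 3 (0.07 log units; within the scatter). Each was within the scatter. The step from compound 1 to compound 2, a 1.5-fold higher number from compound 1 to compound 2 (0.16 log units; within the scatter), a single substituent on that aryl ring, was also within the scatter. Nothing in these data separates one substituted phenyl from another beyond the scatter, so for compound 4 no step beyond the scatter is expected in this assay in either direction.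

Compound 4 is therefore estimated at 30000 nM, with a range of 12000 nM to 75000 nM. The step this estimate means is a 1.1-fold lower number from compound 3 to compound 4 (0.05 log units; within the scatter), an expected change no larger than the scatter.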

Compound 4, half-maximal inhibitory concentration: 10000 nM
Compound 4: middle estimate off by 3.0-fold (0.48 log units), on the high side, and the stated range ends above it.
By their numbers in this assay, from the lowest: compounds 4, 1, 2 and 3 (each within the scatter of the next, the first and the last beyond it).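

In this assay, a change of the aryl group on the saturated ring carbon now moves the number beyond the scatter, though only modestly, in two steps (a 3.4-fold lower number from compound 3 to compound 4 (0.53 log units; beyond the scatter); a 2.9-fold lower number from compound 2 to compound 4 (0.46 log units; beyond the scatter)), whereas every step among the three earlier compounds stayed within it. The separation is not general to this position, since 3,4-dichlorophenyl stays within the scatter of the plain phenyl (a 2.0-fold lower number from compound 1 to compound 4 (0.30 log units; within the scatter)), so the data set it apart only from the 2-chlorophenyl and 2,4-difluorophenyl groups. No measurement on hand accounts for these steps.

Within the data shown here, whether both chlorine atoms of the 3,4-dichlorophenyl group are needed for these steps stays open, as the only other chlorinated aryl group in the set is 2-chlorophenyl. Also open, on these data alone, is how this assay would read an aryl group carrying an amine or a carboxylic acid, or a pyridine ring in place of the phenyl ring at this position.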